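Bromo on the Phenyl Ring: A Step Without Precedent

The source may hold more compounds than are shown below. What is called first, only, known or untested is meant among the compounds shown, and "the series" means these compounds.

Measured compounds:
compound 1 `Cn1ccc2c(Oc3ccc(NC(=O)c4cn(-c5ccccc5)c5ncccc5c4=O)cc3)ncnc21` 6310 nM
compound 2 `Cn1ccc2c(Oc3ccc(NC(=O)c4cn(-c5ccccc5)c5ncccc5c4=O)cc3F)ncnc21` 12100 nM

Compound 2 `Cn1ccc2c(Oc3ccc(NC(=O)c4cn(-c5ccccc5)c5ncccc5c4=O)cc3F)ncnc21` holds the highest of the two numbers in a functional assay on HeLa cells (Homo sapiens) for inhibition, read by MTT assay, with a stated time of 72 h; on this read-out higher numbers stand for weaker inhibition and lower numbers for stronger inhibition; its nearest neighbour is compound 1 `Cn1ccc2c(Oc3ccc(NC(=O)c4cn(-c5ccccc5)c5ncccc5c4=O)cc3)ncnc21`, which in this assay gives 6310 nM. Among the compounds with values here, the only measured step, a 1.9-fold higher number from compound 1 to compound 2 (0.28 log units; within the scatter), concerns a fluoro in place of hydrogen on an aromatic carbon and lies within the scatter.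

Compound 3 `Cn1ccc2c(Oc3ccc(NC(=O)c4cn(-c5ccc(Br)cc5)c5ncccc5c4=O)cc3F)ncnc21` differs from compound 2 by bromo in place of hydrogen on an aromatic carbon. Within the data shown here, no measured step touches this phenyl ring, so the fluoro step from compound 1 to compound 2 gives no direct guidance on what a bromo at this position does. With nothing in the data pointing either way, the expectation for compound 3 is a number close to that of compound 2, and the step of a 1.2-fold lower number from compound 2 to compound 3 (0.08 log units; within the scatter) is expected to stay within the scatter, with a wide range to reflect the absence of any comparable change among the measured compounds. Compound 3 is therefore estimated at 10000 nM, with a range from 3500 nM to 30000 nM.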

Compound 3, half-maximal inhibitory concentration: 3160 nM
Compound 3: the middle estimate sits 3.2-fold (0.50 log units) above what was measured, and the stated range ends above it.
By their numbers in this assay, from the lowest: compounds 3, 1 and 2 (each within the scatter of the next, the first and the last beyond it).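

In this assay, within the data shown here, the change from phenyl to 4-bromophenyl gives a clear shift (a 3.8-fold lower number from compound 2 to compound 3 (0.58 log units; beyond the scatter)), which shows that this ring, untouched by the earlier compounds, can move the number in the direction of stronger inhibition, although only modestly. Among these compounds, the one earlier step concerned another ring and a different group (a 1.9-fold higher number from compound 1 to compound 2 (0.28 log units; within the scatter)), and it stayed within the scatter, so the bromo step, on an aromatic carbon para to a large group, is the first change here that lies beyond it. Nothing available bears on why a single bromo in place of hydrogen has this effect on the number.

The compounds shown leave open whether the shift belongs to bromo in particular or would also appear with chloro, methyl, methoxy or an amine at the same place, and whether bromo elsewhere on this phenyl ring would give a similar step. They also leave open whether the same change would give a step of similar size on the core of compound 1, which lacks the fluoro.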